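This account rests on a few compounds, and the source may have more. Where it says the series, first, only, none or still open, it means among the compounds named here.

Working notes on the hydroxyproline-serine series in an ADME assay for metabolic stability, read by HPLC, in simulated gastric fluid, with a stated time of 12 h, at pH 1.2; a higher number here means that the compound lasts longer, a lower number that the compound disappears faster. Compound 1 `O=C(O)[C@H](CO)NC(=O)[C@H]1C[C@H](O)CN1` gives only a limit there, > 12 h. Compound 2 `O=C(O)[C@H](CO)NC(=O)[C@@H]1C[C@@H](O)CN1` likewise reaches the limit, > 12 h. Compound 3 `O=C(O)[C@@H](CO)NC(=O)[C@H]1C[C@@H](O)CN1` also stops at the limit, > 12 h. Compound 4 `O=C(O)[C@H](CO)NC(=O)[C@@H]1C[C@H](O)CN1` is not yet measured in this assay. Its change from compound 1: the two compounds have the same atoms and bonds and differ only in configuration as drawn: 1 of 3 stereo elements differ; a stereocentre at a saturated ring carbon is drawn R in compound 1 and S in compound 4. The measured steps that bear on it are configurational changes as well: a step that the two limits leave unreadable from compound 1 to compound 2, a step that the two limits leave unreadable from compound 1 to compound 3 and a step that the two limits leave unreadable from compound 2 to compound 3, each without a readable size because of the limit of > 12 h in this assay, at which 3 of the 3 values shown sit; that they are pure changes in configuration follows from the fact that compounds 1 and 2 differ only in the configuration as drawn, the fact that compounds 1 and 3 differ only in the configuration as drawn and (the fact that compounds 2 and 3 differ only in the configuration as drawn). No configurational step here has shown a readable size, so the expected step is a step that the limit leaves unreadable from compound 1 to compound 4, within the scatter. Compound 4 is therefore estimated at 24 h, between 12 h and 60 h, most likely again reported only as a limit in this assay.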

Compound 4, half-life in the ADME assay: > 12 h
Compound 4: a limit, no number; the forecaster's own chance of this, stated with the estimate: 90%; the middle value lies beyond the limit too.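

No step can be read for compound 4 against compound 1, compound 2 or compound 3 in the ADME assay, where all four values are limits. In a physicochemical assay for metabolic stability, read by HPLC, in phosphate buffer, with a stated time of 12 h, at pH 7.2 (on this read-out higher numbers stand for a longer-lived compound and lower numbers for a shorter-lived compound), compound 1 gives a limit, > 12 h. In the physicochemical assay compound 4 also gives a limit, > 12 h. The compounds shown leave open whether any change in configuration alters the half-life at all.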